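Benzothiazole amides against prostate cancer cells: swapping a chloro

A few compounds are considered here, and "the series" means these few. Any claim that something is new, unique, unknown or untested is made for them only; others in the source may bear on it.

Measured so far:
- compound 1 `O=C(Nc1nc2ccc(Cl)cc2s1)c1cc(-c2ccc(F)cc2)n2nc(-c3ccccc3)cc2n1` gives 17600 nM
- compound 2 `COc1ccc(-c2cc(C(=O)Nc3nc4ccc(Cl)cc4s3)nc3cc(-c4ccccc4)nn23)cc1` gives 5880 nM

Both compounds were tested in a functional assay on DU-145 cells (Homo sapiens) for cytotoxicity, read by MTT assay, with a stated time of 48 h; on this read-out higher numbers stand for weaker inhibition and lower numbers for stronger inhibition. Among the compounds with values here, compound 2 has the lower of the two numbers; the only measured step, a 3.0-fold lower number from compound 1 to compound 2 (0.48 log units; beyond the scatter), separates it from compound 1 and lies beyond the scatter. The next compound, compound 3 `COc1ccc(-c2cc(C(=O)Nc3nc4ccc(OC)cc4s3)nc3cc(-c4ccccc4)nn23)cc1`, is not yet measured. It differs from compound 2 by methoxy in place of chloro on an aromatic carbon. Within the data shown here, no measured step touches this position: the one step available, a 3.0-fold lower number from compound 1 to compound 2 (0.48 log units; beyond the scatter), concerns a different ring and a different leaving group, so it offers only a weak hint that a methoxy can sit on an aromatic carbon without harming potency. On that thin basis no step beyond the scatter is expected in this assay for compound 3, though the estimate carries wide uncertainty. For compound 3 the expected value is 6500 nM, with a range from 2200 nM to 20000 nM. This estimate corresponds to an expected step of a 1.1-fold higher number from compound 2 to compound 3 (0.04 log units; within the scatter).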

Compound 3, half-maximal inhibitory concentration: 7580 nM
Estimate against measurement, compound 3: 1.2-fold (0.07 log units) below; measured number inside the range.
By their numbers in this assay, from the lowest: compounds 2 and 3 (each within the scatter of the next); then compound 1.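

Replacing 6-chloro-1,3-benzothiazol-2-yl with 6-methoxy-1,3-benzothiazol-2-yl gives a 1.3-fold higher number from compound 2 to compound 3 (0.11 log units; within the scatter) in this assay, so this read-out does not separate the two groups at this position. Within the data shown here, the earlier step, a 3.0-fold lower number from compound 1 to compound 2 (0.48 log units; beyond the scatter), lay in a different place on the molecule, which makes this the first reading at this position: here a single chlorine atom can give way to a methoxy, with its two heavy atoms and one hydrogen-bond acceptor, without a step beyond the scatter. Nothing measured here speaks to the reason for this result.

The compounds shown leave open whether an amine, a carboxylic acid or a longer chain such as ethoxy at this position would read like chloro and methoxy, or would shift the number beyond the scatter. They also leave open whether the same exchange would read alike in a compound that carries the fluoro of compound 1 instead of the other methoxy, so the result cannot yet be taken as a rule for the whole series.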